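The compounds below may be only part of what the source reports. "The series", "measured", "known", "first", "only" and "open" are said of these compounds alone.

Measured so far:
- compound 1, `C/N=C(/NC#N)NCCCCCCn1nc(-c2ccccc2)ccc1=O`, 31.7% in a functional assay on the whole organism with Rattus norvegicus as the target, at a dose of 100 mg/kg; a lower number here means less inhibition, a higher number more inhibition at the dose given (going by the name of the read-out)
- compound 2, `CCC/N=C(/NC#N)NCCCn1nc(C)ccc1=O`, 17.5%
- compound 3, `CC/N=C(\S)NCCCCn1nc(-c2ccccc2)ccc1=O`, 67.7%

Compound 1 gives the second highest of the three numbers in this assay. Its nearest neighbour is compound 2, whose number is lower by a gap beyond the scatter of repeated measurements; compound 3 stands furthest away, with a number higher than that of compound 1 by a gap also beyond the scatter. The unmeasured compound 4, `CN(C)/C(=N/CCCCCn1nc(-c2ccccc2)ccc1=O)NC#N`, is built from the same atoms as compound 1, joined differently. The change is this: a group of 8 heavy atoms (4 carbon, 4 nitrogen; no ring) in place of a group of 8 heavy atoms (4 carbon, 4 nitrogen; no ring), on a saturated chain carbon, five bonds along the chain from an aromatic nitrogen. For the measured compounds named here, no pair of measured compounds differs in only one place, so no measured step of this kind exists to guide the expectation. Given that, compound 4 is expected to land near compound 1, with a step of a number 1.7 percentage points lower from compound 1 to compound 4 (within the scatter) that stays within the scatter. Compound 4 is therefore expected to give an inhibition of 30%, within a range from 10% to 55%.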

Compound 4, a percentage reported as inhibition, in the whole organism at one dose (the size of the read-out at that dose, not a potency): 63.9%
Compound 4: middle estimate off by 33.9 percentage points, on the low side; the measured number lies above the stated range.
By their numbers in this assay, from the lowest: compound 2; then compound 1; then compounds 4 and 3 (each within the scatter of the next).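

In this assay, exchanging one group for another built from the same heavy atoms, on a saturated chain carbon, five bonds along the chain from an aromatic nitrogen, gives a number 32.2 percentage points higher from compound 1 to compound 4 (beyond the scatter) in a single step. This shows that the number at this position can shift strongly even when the atoms stay the same and only their joining differs; the counted difference between the groups is that the leaving group has 2 hydrogen-bond donors and the entering group has 1. Nothing measured here bears on why the number rises.

This single step cannot show whether the donor count matters or whether another feature of the rearrangement does. It also leaves open how a simple amine or a carboxylic acid would behave at this position.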